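The compounds below may be only part of what the source reports. "The series", "measured", "known", "first", "only" and "open" are said of these compounds alone.

Measured in a functional assay on HeLa cells (Homo sapiens) for cytotoxicity, read by MTT assay, with a stated time of 48 h; on this read-out higher numbers stand for weaker inhibition and lower numbers for stronger inhibition:
- compound 1 `C=CC(C)(O)CC[C@@H]1C(=C)CC[C@H](Br)[C@@]1(C)CCC(Br)C(C)(C)O`: 91800 nM; 47400 nM (2 entries)
- compound 2 `C=CC(C)(O)CC[C@@H]1C(=C)CC[C@H](Br)[C@@]1(C)CCC(OC)C(C)(C)O`: > 100000 nM

For compound 2, > 100000 nM is a limit of the assay and not a number, so its position is known only as a limit. Compound 3 `C=CC(C)(O)CC[C@@H]1C(=C)CC[C@H](Br)[C@@]1(C)CCC1OC1(C)C` has not yet been measured. It differs from compound 2 as follows: 3,3-dimethyloxiran-2-yl in place of 2-hydroxy-1-methoxy-2-methylpropyl on a saturated chain carbon, two bonds along the chain from a saturated ring carbon. The 3,3-dimethyloxiran-2-yl group thus takes the place of 2-hydroxy-1-methoxy-2-methylpropyl on a saturated chain carbon, two bonds along the chain from a saturated ring carbon. For the measured compounds named here, no measured step between compounds differing in one place is available, so the expectation leans on compound 1 at 91800 nM; 47400 nM (2 entries). A modest move towards stronger inhibition is expected, shown as an at least 1.6-fold lower number from compound 2 to compound 3 (0.22 log units; that floor lies within the scatter). For compound 3, the estimated value is 60000 nM, with an expected range of 25000 nM to 150000 nM.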

Compound 3, half-maximal inhibitory concentration: 57900 nM
Compound 3: the middle estimate sits 1.0-fold (0.02 log units) above what was measured; measured number inside the range.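

In this assay, compound 3 shows that with 3,3-dimethyloxiran-2-yl on this saturated chain carbon the series still gives a number, where compound 2, with 2-hydroxy-1-methoxy-2-methylpropyl, gave only a limit. For compound 2, > 100000 nM is a limit of the assay and not a number. The change therefore reads as an at least 1.7-fold lower number from compound 2 to compound 3 (0.23 log units; that floor lies within the scatter), and its true size stays unknown because one end of the step is a limit: the limit of > 100000 nM in this assay, at which 1 of the 3 values shown sits.

The change takes away the methoxy and the hydroxy and brings in the three-membered ring in one move, and the compounds shown do not separate these parts. As far as these compounds go, how an amine or a longer chain at this place would read in this assay also stays open.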